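This account rests on a few compounds, and the source may have more. Where it says the series, first, only, none or still open, it means among the compounds named here.

In an ADME assay on the whole organism (Mus musculus, strain BALB/c) for pharmacokinetics, read by LC-MS, with a stated time of 600 min, at a dose of 20 mg/kg by the intravenous route (a higher number here means that a larger share of the oral dose reaches the circulation, a lower number that a smaller share of the oral dose reaches the circulation), compound 1 `CN(CCCNC(=O)Nc1ccc(C(C)(C)C)cc1)C[C@H]1C[C@@H](c2ccc3c(N)ncnn23)[C@H](O)[C@@H]1O` reads 0.3% while compound 2 `CC(C)NC[C@@H]1C[C@H](c2ccc3c(N)ncnn23)[C@@H](O)[C@H]1O` reads 12% and so stands as the higher of the two, with a gap beyond the scatter. The next compound to be measured is compound 3 `CC(C)NC[C@H]1C[C@@H](c2ccc3c(N)ncnn23)[C@H](O)[C@@H]1O`, and its structural difference from compound 2 is this: the two compounds have the same atoms and bonds and differ only in configuration as drawn: 4 of 4 stereo elements differ (all stereocentres are inverted: mirror images); a stereocentre at a saturated ring carbon is drawn S in compound 2 and R in compound 3; a stereocentre at a saturated ring carbon is drawn R in compound 2 and S in compound 3; a stereocentre at a saturated ring carbon is drawn R in compound 2 and S in compound 3; a stereocentre at a saturated ring carbon is drawn S in compound 2 and R in compound 3 and nothing else separates them. Going by the values given here, no measured pair of mirror images is available to show how far such an inversion moves the number in this assay, so the data give no direction. The expectation therefore rests on compound 2 at 12% as the closest reference, and no step beyond the scatter is expected. The expected result is a number 2 percentage points lower from compound 2 to compound 3 (within the scatter) and this estimate lies within the scatter. For compound 3 the estimated value is 10% with an expected range from 3% to 25% in this measurement.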

Compound 3, oral bioavailability: 9%
Estimate against measurement, compound 3: 1 percentage points above; the range from low to high includes it.
By their numbers in this assay, from the lowest: compounds 1, 3 and 2 (each within the scatter of the next, the first and the last beyond it).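

In this assay, going by these compounds alone, compounds 2 and 3 form the first pair of mirror images, and the result is a number 3 percentage points lower from compound 2 to compound 3 (within the scatter). In this pair, then, inverting all the stereocentres together does not separate the two compounds beyond the usual scatter of the measurement, something compound 1 could not show alongside compound 2, as those two differ in more than one place. The comparison is a clean reading of configuration alone, and it rests on one fact: the fact that compounds 2 and 3 differ only in the configuration as drawn

The compounds shown leave open whether inverting only some of the stereocentres would give a step of similar size. They also leave open whether mirror images would stay as close with a cyclopropyl group, a longer chain or a carboxylic acid on the amine.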